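A few compounds are considered here, and "the series" means these few. Any claim that something is new, unique, unknown or untested is made for them only; others in the source may bear on it.

Measured in a physicochemical assay for lipophilicity, read by HPLC, measured as chromatographic lipophilicity; a lower number here means a more polar compound, a higher number a more lipophilic compound
- compound 1 `CCC/N=C1\S/C(=C\c2ccc(C(=O)OCCO)cc2)C(=O)N1c1ccccc1C` gives 3.4
- compound 2 `CCC/N=C1\S/C(=C\c2ccc(C(=O)NCCO)cc2)C(=O)N1c1ccccc1C` gives 2.3
- compound 3 `CCC/N=C1\S/C(=C\c2ccc(C(=O)NCC(=O)N(C)C)cc2)C(=O)N1c1ccccc1O` gives 1.9

Compound 3 has the lowest number of the three. Going to compound 4 `CCC/N=C1\S/C(=C\c2ccc(C(=O)OCC(O)CO)cc2)C(=O)N1c1ccccc1O` puts 2,3-dihydroxypropoxy in place of ((dimethylcarbamoyl)methyl)amino on a carbonyl carbon. For the measured compounds named here, one measured step bears on this: (2-hydroxyethyl)amino in place of 2-hydroxyethoxy on a carbonyl carbon (a number 1.10 log units lower from compound 1 to compound 2 (beyond the scatter)), a large step. The present change runs the opposite way, with an amino group leaving and an alkoxy group entering. Compound 1 and compound 2 also differ from compound 3 elsewhere in the structure, so the transfer is uncertain. In this assay a rise somewhat smaller than that step is expected. The estimated change is a number 0.80 log units higher from compound 3 to compound 4 (beyond the scatter) and remains an expectation. For compound 4 the expected value is 2.7 with an estimated range from 2.2 to 3.2 for now.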

Compound 4, distribution coefficient: 1.8
Compound 4: the middle estimate sits 0.90 log units above what was measured; the whole stated range lies above it.
By their numbers in this assay, from the lowest: compounds 4 and 3 (each within the scatter of the next); then compound 2; then compound 1.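

In this assay 2,3-dihydroxypropoxy in place of ((dimethylcarbamoyl)methyl)amino on this carbonyl carbon gives a number 0.10 log units lower from compound 3 to compound 4 (within the scatter), so an alkoxy group entering for an amino group here need not come with a large step. The earlier step, a number 1.10 log units lower from compound 1 to compound 2 (beyond the scatter), therefore does not set a fixed size for this kind of exchange, although both chains differ here as well. No measured evidence accounts for this result.

As far as these compounds go, whether (2,3-dihydroxypropyl)amino on the same carbonyl carbon would separate the link from the chain stays open. From the compounds shown here alone, how far the other structural difference between compound 2 and compound 3 matters also stays open.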